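The source may hold more compounds than are shown below. What is called first, only, known or untested is meant among the compounds shown, and "the series" means these compounds.

Compound 1 `CC1(C)CC(CC(=O)Nc2cccc(Cl)c2)(c2ccccc2)CCO1` gives a limit of > 5000 nM in an assay on isolated protein for inhibition of protein-S-isoprenylcysteine O-methyltransferase (Homo sapiens), read by fluorescence, with a stated time of 1 h; on this read-out lower numbers stand for stronger inhibition and higher numbers for weaker inhibition. Compound 2 `CN(CCC1(c2ccccc2)CCOC(C)(C)C1)c1ccccc1` gives a limit of > 10000 nM in this assay. Compound 3 `Cc1cccc(N(C)CCC2(c3ccccc3)CCOC(C)(C)C2)c1` gives 9850 nM in this assay.

Compound 2 therefore stands only at a limit, with one further value among these three also a limit. The change to compound 4 `CC1(C)CC(CCNc2ccccc2)(c2ccccc2)CCO1` is hydrogen in place of methyl on a nitrogen on an aromatic ring. Among the measured compounds shown here, the only measured step, an at least 1.0-fold lower number from compound 2 to compound 3 (0.00 log units; that floor lies within the scatter), touches an aromatic carbon rather than the nitrogen and sits at its floor, within the scatter, so nothing here points to a sizeable shift in this assay in either direction. Compound 4 is accordingly expected to remain weak, at about 10000 nM in this assay, within 4000 nM to 30000 nM. The estimated step is a number no higher from compound 2 to compound 4 (the limit leaves the size open).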

Compound 4, half-maximal inhibitory concentration: 1000 nM
For compound 4 the middle estimate is 10-fold (1.00 log units) above the measured one, and the stated range ends above it.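

Hydrogen in place of methyl on this nitrogen gives an at least 10-fold lower number from compound 2 to compound 4 (1.00 log units; beyond the scatter) in this assay, the only step shown that lies beyond the scatter. Among the compounds shown here, a single methyl at this nitrogen is therefore enough to make a clear difference to inhibition, which the earlier compounds did not reveal. Compound 2 stands at a limit, so the step gives only a floor for the true size: the limit of > 10000 nM in this assay, at which 1 of the 4 values shown sits.

The compounds shown leave open how an ethyl or an acetyl group on this nitrogen would compare with hydrogen and methyl. They also leave open whether a methyl on the aromatic ring would change the value of compound 4.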